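Solubility of a Cyclobutyl Analogue of Compound 2

The source may report more compounds than this note shows. Statements on the series, on what has been measured and on what is new or still open speak of the compounds shown alone.

Measured so far:
compound 1 `Fc1ccc(Nc2cc3[nH]c(Nc4ccc(N5CCN(C6CC6)CC5)cn4)nc3cn2)cc1C(F)(F)F` — 5000 nM
compound 2 `Fc1ccc(Nc2cc3[nH]c(Nc4ccc(N5CCN(CC6CC6)CC5)cn4)nc3cn2)cc1C(F)(F)F` — 75000 nM

In a physicochemical assay for solubility, read by HPLC, using the shake flask method, in phosphate buffer, measured as kinetic solubility, with a stated time of 20 h, at pH 6.5 (a higher number here means a more soluble compound, a lower number a less soluble compound), compound 1 gives 5000 nM and compound 2 gives 75000 nM. For the measured compounds named here, compound 2 thus stands highest of the two numbers, with compound 1 its only neighbour; the single measured step, a 15-fold higher number from compound 1 to compound 2 (1.18 log units; beyond the scatter), is large and beyond the scatter, and it changes the group on the amine nitrogen in the ring.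

Compound 3 `FC1(F)CC(Nc2cc3[nH]c(Nc4ccc(N5CCN(CC6CC6)CC5)cn4)nc3cn2)C1` is the next compound. It differs from compound 2 at another place: 3,3-difluorocyclobutyl in place of 4-fluoro-3-(trifluoromethyl)phenyl on a nitrogen on an aromatic ring. Going by the values given here, no measured step touches this place, so the one step from compound 1 to compound 2 bears on it only as a sign that this series can move widely in this assay, not as a guide to direction. The change removes an aromatic ring and enters a smaller, non-aromatic ring, and on that basis a moderate rise beyond the scatter is expected, a 2.7-fold higher number from compound 2 to compound 3 (0.43 log units; beyond the scatter), though with wide uncertainty. Compound 3 is therefore estimated at 200000 nM, within a range from 50000 nM to 800000 nM.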

Compound 3, solubility: 190000 nM
Beside the measured number, compound 3's estimate is 1.1-fold (0.02 log units) above it, within the range that was stated.
By their numbers in this assay, from the lowest: compound 1; then compound 2; then compound 3.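

For the compounds shown here, the step gives the only reading at this position, on a nitrogen on an aromatic ring, whereas the earlier step concerned the amine nitrogen in a ring. In this assay the replacement of 4-fluoro-3-(trifluoromethyl)phenyl by 3,3-difluorocyclobutyl gives a 2.5-fold higher number from compound 2 to compound 3 (0.40 log units; beyond the scatter) and so shows that this position, too, can shift the read-out beyond the scatter, though this modest step is smaller than the large one of a 15-fold higher number from compound 1 to compound 2 (1.18 log units; beyond the scatter) at the other place. The exchange also shows that, with compound 2 as the reference, the six-membered aromatic ring of 11 heavy atoms can give way to a four-membered non-aromatic ring of 6 heavy atoms with no loss in this read-out, yet it alters ring size, aromaticity and fluorine count at once, so this single step does not separate them.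

Plain cyclobutyl, unsubstituted phenyl and a cyclobutyl bearing an amine or a carboxylic acid would each bear on that question, but none of them is among the compounds shown. Nothing presented here gives a measured explanation for the rise in this step.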